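A few compounds are considered here, and "the series" means these few. Any claim that something is new, unique, unknown or untested is made for them only; others in the source may bear on it.

Compound 1 `Cc1cccc(C(=O)n2c(-c3cn(-c4ccccc4)nc3-c3ccc(C(F)(F)F)cc3)nc3ccccc32)c1` is the reference point; in an ADME assay on HEK-293T cells (Homo sapiens) for cytotoxicity, read by MTT assay, with a stated time of 24 h (on this read-out lower numbers stand for higher toxicity in this test and higher numbers for lower toxicity in this test), compound 1 gives 154000 nM. Its one companion, compound 2 `O=C(c1ccc(Cl)cc1)n1c(-c2cn(-c3ccccc3)nc2-c2ccc(C(F)(F)F)cc2)nc2ccccc21`, gives 181000 nM in this assay, and the step of a 1.2-fold higher number from compound 1 to compound 2 (0.07 log units; within the scatter) does not separate the two, so compound 1 stands together with compound 2 rather than apart from it. The unmeasured compound 3 `Cc1cccc(C(=O)n2c(-c3cn(-c4ccccc4)nc3-c3ccc(F)cc3)nc3ccccc32)c1` differs from compound 1 by fluoro in place of trifluoromethyl on an aromatic carbon. Among the compounds with values here, the only measured step, a 1.2-fold higher number from compound 1 to compound 2 (0.07 log units; within the scatter), alters the aryl on the carbonyl carbon and leaves the 4-(trifluoromethyl)phenyl untouched, so no measured step bears directly on the change to compound 3, and that one step was itself within the scatter. No step beyond the scatter is therefore expected in this assay in either direction. For compound 3 the expected value is 154000 nM, with a range from 70000 nM to 340000 nM. The expected step of no change at the digits printed from compound 1 to compound 3 (within the scatter) should sit within the scatter.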

Compound 3, half-maximal cytotoxic concentration: 148000 nM
Compound 3: middle estimate off by 1.0-fold (0.02 log units), on the high side; the range from low to high includes it.
By their numbers in this assay, from the lowest: compounds 3, 1 and 2 (each within the scatter of the next).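

In this assay, the 4-(trifluoromethyl)phenyl now has a measured exchange of its own: a 1.0-fold lower number from compound 1 to compound 3 (0.02 log units; within the scatter). Trifluoromethyl, with 4 heavy atoms, and fluoro, with 1 heavy atom, are therefore not separated at this place, and this step joins a 1.2-fold higher number from compound 1 to compound 2 (0.07 log units; within the scatter), made on the aryl at the carbonyl carbon, in staying within the scatter, so neither of the two places varied so far has produced a separable step. Nothing measured here speaks to the reason for this result. Still open, going by these compounds, is whether an amine or a carboxylic acid in place of fluoro at this position would give a step beyond the scatter. Also open, on these data alone, is how the 4-chlorophenyl on the carbonyl carbon reads when paired with the 4-fluorophenyl.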